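Swapping a Phenylthiazoline for a Thiazolinone on Pyrazoline Cores

The compounds below may be only part of what the source reports. "The series", "measured", "known", "first", "only" and "open" are said of these compounds alone.

The measured compounds in a functional assay on BGC-823 cells (Homo sapiens) for inhibition, read by CCK-8 assay, with a stated time of 48 h (on this read-out higher numbers stand for weaker inhibition and lower numbers for stronger inhibition), are these:
compound 1, `Fc1ccc(C2=NN(C3=NC(c4ccccc4)CS3)C(c3ccc4ccccc4c3)C2)cc1`, gives 17300 nM;
compound 2, `O=C1CSC(N2N=C(c3ccc(F)cc3)CC2c2ccc3ccccc3c2)=N1`, gives 14900 nM;
compound 3, `Brc1ccc(C2=NN(C3=NC(c4ccccc4)CS3)C(c3cccc4ccccc34)C2)cc1`, gives 17400 nM.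

Compound 2 differs from compound 1 by one change, (a group of 6 heavy atoms (3 carbon, 1 nitrogen, 1 oxygen, 1 sulfur; one five-membered non-aromatic ring with 2 hetero atoms) in place of a group of 11 heavy atoms (9 carbon, 1 nitrogen, 1 sulfur; one five-membered non-aromatic ring with 2 hetero atoms, one six-membered aromatic ring of carbon only), on an amine nitrogen in a ring). That change made a 1.2-fold lower number from compound 1 to compound 2 (0.06 log units; within the scatter). Compound 3 shares a related core with compound 1, but the difference between the two cores is not broken down here; their values in this assay sit within the scatter of each other.

Compound 4, `O=C1CSC(N2N=C(c3ccc(Br)cc3)CC2c2cccc3ccccc23)=N1`, has not been measured. It differs from compound 3 by a group of 6 heavy atoms (3 carbon, 1 nitrogen, 1 oxygen, 1 sulfur; one five-membered non-aromatic ring with 2 hetero atoms) in place of a group of 11 heavy atoms (9 carbon, 1 nitrogen, 1 sulfur; one five-membered non-aromatic ring with 2 hetero atoms, one six-membered aromatic ring of carbon only), on an amine nitrogen in a ring. Within the data shown here, this is the same kind of change as the one from compound 1 to compound 2, though the surroundings differ: here the place is next to the ring atom that bears a naphthalen-1-yl group and two ring bonds from the ring atom that bears a 4-bromophenyl group, whereas there it was a naphthalen-2-yl group and a 4-fluorophenyl group.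

For compound 4 the step is expected to be a 1.2-fold lower number from compound 3 to compound 4 (0.06 log units; within the scatter), essentially flat, because a 1.2-fold lower number from compound 1 to compound 2 (0.06 log units; within the scatter) was within the scatter. Compound 4 is therefore estimated at 15000 nM, with a likely range from 7500 nM to 30000 nM.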

Compound 4, half-maximal inhibitory concentration: 14600 nM
Beside the measured number, compound 4's estimate is 1.0-fold (0.01 log units) above it; the range from low to high includes it.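

In this assay the same exchange on the amine nitrogen in a ring made a 1.2-fold lower number from compound 3 to compound 4 (0.08 log units; within the scatter) and thus matched the earlier step: the same change on two cores in this assay, a 1.2-fold lower number (0.06 log units; within the scatter) from compound 1 to compound 2 and a 1.2-fold lower number (0.08 log units; within the scatter) from compound 3 to compound 4, 1.0-fold (0.01 log units) apart, within the scatter of two such steps. Across these two pairs the change therefore carries over as a flat step, even though one pair bears naphthalen-2-yl and 4-fluorophenyl groups and the other naphthalen-1-yl and 4-bromophenyl groups. This does not show that the smaller group gives any gain over the larger one, and two pairs in one cell assay cannot show that the change would stay flat on other cores.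

The compounds shown leave open what the naphthalen-1-yl and naphthalen-2-yl groups do on their own, and likewise the 4-fluorophenyl and 4-bromophenyl groups, as the two cores differ at both places at once. They also leave open whether an amine or a carboxylic acid on the phenyl ring would move the read-out at all.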